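This account rests on a few compounds, and the source may have more. Where it says the series, first, only, none or still open, it means among the compounds named here.

Measured so far in a functional assay on MCF7 cells (Homo sapiens) for antiproliferative activity, read by MTT assay, with a stated time of 72 h; on this read-out higher numbers stand for weaker inhibition and lower numbers for stronger inhibition:

- compound 1, `O=C(COc1ccc(C(=O)/C=C/c2ccc(Cl)cc2Cl)cc1)N[C@H]1CCOC1=O`: compound 1 gives 34400 nM
- compound 2, `Cc1ccc(C(C)C)c(OCCSC(=S)N[C@H]2CCOC2=O)c1`: compound 2 gives only a limit, > 64000 nM
- compound 3, `O=C1OCC[C@@H]1NC(=S)SCCOc1ccccc1`: compound 3 gives only a limit, > 64000 nM

Within the data shown here, compound 1 is the only compound with an actual number; it stands as a weak inhibitor, yet it is the one point from which anything can be read. Compound 2 and compound 3 both sit at the limit of > 64000 nM in this assay, at which 2 of the 3 values shown sit, so they give no number to compare with. Among the measured compounds shown here, no pair of measured compounds differs in a single place, so no step has been measured.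

Compound 4, `O=C(COc1ccc(C(=O)/C=C/c2ccc(F)cc2)cc1)N[C@H]1CCOC1=O`, differs from compound 1 in one place: 4-fluorophenyl in place of 2,4-dichlorophenyl on a double-bonded chain carbon bound to a double-bonded chain carbon. For the measured compounds named here, with no measured step of this kind, the expectation rests on compound 1 alone. The step from compound 1 to compound 4 in this assay is expected to be small, likely toward weaker inhibition, and possibly no larger than the usual scatter. Compound 4 is therefore estimated at 45000 nM, with a range from 15000 nM to 64000 nM, a step of a 1.3-fold higher number from compound 1 to compound 4 (0.12 log units; within the scatter).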

Compound 4, half-maximal inhibitory concentration: > 64000 nM
Compound 4 ended at the assay's limit; the forecaster's own chance of this, stated with the estimate: 30%; middle value at least 1.4-fold (0.15 log units) from the limit.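

Compound 4 gives > 64000 nM in this assay, and this is a limit of the assay, not a number. Among these compounds, putting 4-fluorophenyl in place of 2,4-dichlorophenyl on a double-bonded chain carbon bound to a double-bonded chain carbon gives the first measured step at this position, an at least 1.8-fold higher number from compound 1 to compound 4 (0.26 log units; that floor lies within the scatter), so only a lower bound on its size is known, and that bound cannot separate a real loss from repeat scatter. Compound 1 therefore remains the only compound here with an actual number: the limit of > 64000 nM in this assay, at which 3 of the 4 values shown sit.

The change swaps both chlorines for one fluorine at once, so a 4-chlorophenyl group would be needed to show what each part of the swap contributes. On these data alone, whether another group at this position, such as 4-methoxyphenyl, would give stronger inhibition than compound 1 also remains open.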